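The compounds below may be only part of what the source reports. "The series", "measured", "known", "first", "only" and "open" are said of these compounds alone.

Compound 1 `O=S(=O)(/C=C/c1ccccn1)c1cccc(F)c1` is the starting point. In an assay on U2OS cells for activation of nuclear factor erythroid 2-related factor 2 (Homo sapiens), read by beta-arrestin recruitment, with a stated time of 6 h (a higher number here means that more compound is needed for the effect, a lower number that less compound is needed), compound 1 gives 1680 nM. Compound 2 `O=S(=O)(/C=C/c1ncccc1F)c1cccc(F)c1` carries a single change relative to compound 1: fluoro in place of hydrogen on an aromatic carbon. In this assay compound 2 gives 474 nM, and the step of a 3.5-fold lower number from compound 1 to compound 2 (0.55 log units; beyond the scatter). Compound 3 `O=S(=O)(/C=C/c1ccccn1)c1ccccc1Cl` has a different core; the difference between the two cores is not broken down here. In this assay compound 3 gives 618 nM, a lower number than compound 1 shows. Compound 4 `O=S(=O)(/C=C/c1ncccc1F)c1ccccc1Cl` has not been measured. It differs from compound 3 by the same change, (fluoro in place of hydrogen on an aromatic carbon), at a place described in the same words as before. A step of similar size is expected here, a 3.1-fold lower number from compound 3 to compound 4 (0.49 log units; beyond the scatter), because the same change earlier gave a 3.5-fold lower number from compound 1 to compound 2 (0.55 log units; beyond the scatter). On that basis compound 4 is estimated to give about 200 nM in this assay, with a likely range from 90 nM to 450 nM.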

Compound 4, half-maximal effective concentration: 122 nM
For compound 4 the middle estimate is 1.6-fold (0.21 log units) above the measured one, and the stated range covers the measured number.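

In this assay the swap of hydrogen for fluoro goes the same way on the second core, with a 5.1-fold lower number from compound 3 to compound 4 (0.70 log units; beyond the scatter). The two steps agree in direction, and the gap between them is no larger than repeated measurements would give: the same change on two cores in this assay, a 3.5-fold lower number (0.55 log units; beyond the scatter) from compound 1 to compound 2 and a 5.1-fold lower number (0.70 log units; beyond the scatter) from compound 3 to compound 4, 1.4-fold (0.16 log units) apart, within the scatter of two such steps. The change therefore carried over between these two cores, but two pairs cannot show that it would hold on any further core, and they do not explain how it works.

The compounds shown leave open whether a different group at the same place, such as methyl, methoxy or an amine, would give a similar step. As far as these compounds go, it also remains open whether fluoro elsewhere on that ring would do the same.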